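Hydroxybenzyl isomers on the shared core: cytotoxicity notes

A few compounds are considered here, and "the series" means these few. Any claim that something is new, unique, unknown or untested is made for them only; others in the source may bear on it.

Compound 1 `Oc1ccccc1CNc1ncnc2c1ncn2C1CCCCO1` carries a 2-hydroxyphenyl on a saturated chain carbon bound to a nitrogen on an aromatic ring. In an ADME assay on BJ cells (Homo sapiens) for cytotoxicity, read by MTT assay, with a stated time of 72 h (a higher number here means a weaker inhibitor, a lower number a stronger inhibitor), compound 1 gives only a limit, > 100000 nM. Compound 2 `Oc1cccc(CNc2ncnc3c2ncn3C2CCCCO2)c1` carries a 3-hydroxyphenyl at the same place. In this assay compound 2 likewise gives only a limit, > 100000 nM. The step that the two limits leave unreadable from compound 1 to compound 2 cannot be read, because the limit of > 100000 nM in this assay, at which 2 of the 2 values shown sit, holds both of the values shown. Compound 2 thus stands at the limit of the assay, with no number of its own and no measured neighbour that gives one.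

Compound 3 `Oc1ccc(CNc2ncnc3c2ncn3C2CCCCO2)cc1` differs from compound 2 by 4-hydroxyphenyl in place of 3-hydroxyphenyl on a saturated chain carbon bound to a nitrogen on an aromatic ring. Going by the values given here, the only step so far, from compound 1 to compound 2, is of unreadable size; it offers no direction, only that both hydroxyphenyl variants tried sit at the limit. On that basis no step beyond the scatter is expected in this assay, and compound 3 is estimated to show a step that the limit leaves unreadable from compound 2 to compound 3. Compound 3 is expected to give 150000 nM, within 100000 nM to 300000 nM, most likely reported once more only as a limit.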

Compound 3, half-maximal inhibitory concentration: > 100000 nM
Compound 3: only a limit was reported; the forecaster's own chance of this, stated with the estimate: 85%; the middle value is on the limit's open side.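

No new step can be read from compound 3 to compound 1 or compound 2 in this assay, because the result for compound 3 is again only a limit and the steps among all three compounds stay unreadable: the limit of > 100000 nM in this assay, at which 3 of the 3 values shown sit.

The compounds shown leave open whether the 2-hydroxyphenyl, 3-hydroxyphenyl and 4-hydroxyphenyl variants differ at all in cytotoxicity.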